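Hydroxypropyl to hydroxypentyl: cytotoxicity notes on the series

A few compounds are considered here, and "the series" means these few. Any claim that something is new, unique, unknown or untested is made for them only; others in the source may bear on it.

Measured so far in an ADME assay on HEp-2 cells (Homo sapiens) for cytotoxicity; a lower number here means that less compound is tolerated, a higher number that more compound is tolerated:
- compound 1, `CC(C)S(=O)(=O)CCCn1c(Cn2c(=O)n(C3CC3)c3ccncc32)nc2ccccc21`: 49200 nM
- compound 2, `N#CCCCn1c(Cn2c(=O)n(C3CC3)c3ccncc32)nc2ccccc21`: see below
- compound 3, `O=c1n(Cc2nc3ccccc3n2CCCO)c2cnccc2n1C1CC1`: 245000 nM

Compound 2 gives > 151000 nM; 109000 nM (2 entries), several entries for this compound (the several entries of compound 2 in this assay, > 151000 nM; 109000 nM (2 entries)).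

Compound 3 stands highest of the two single numbers; its nearest neighbour is compound 1, with a 5.0-fold higher number from compound 1 to compound 3 (0.70 log units; beyond the scatter).

Compound 4, `O=c1n(Cc2nc3ccccc3n2CCCCCO)c2cnccc2n1C1CC1`, differs from compound 3 by 2-hydroxyethyl in place of hydroxy on a saturated chain carbon, three bonds along the chain from an aromatic nitrogen. Among the measured compounds shown here, no measured step changes chain length while keeping the hydroxy; the only step in hand swaps the group itself. A step within the scatter is therefore expected in this assay, with no firm direction. Compound 4 is estimated at 200000 nM (range 100000 nM to 400000 nM), an expected step of a 1.2-fold lower number from compound 3 to compound 4 (0.09 log units; within the scatter).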

Compound 4, half-maximal cytotoxic concentration: > 229000 nM
Compound 4 ended at the assay's limit; the forecaster's own chance of this, stated with the estimate: 25%; middle value at least 1.1-fold (0.05 log units) from the limit.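

In this assay compound 4 reads as a limit, not a number: the limit of > 229000 nM in this assay, at which 1 of the 4 values shown sits. The step between compound 3 and compound 4 cannot be read, so lengthening 3-hydroxypropyl to 5-hydroxypentyl has no measured size. With 2-hydroxyethyl in place of isopropylsulfonyl the series shows an at least 4.6-fold higher number from compound 1 to compound 4 (0.66 log units; beyond the scatter), so the longer hydroxy chain also stands clear of the sulfone, as the hydroxypropyl chain did.

Open, from the compounds shown here alone, is whether an amine or a carboxylic acid in place of the hydroxy would lower the number. Going by these compounds, a longer chain than 5-hydroxypentyl is equally open.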